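This account rests on a few compounds, and the source may have more. Where it says the series, first, only, none or still open, it means among the compounds named here.

Working notes on the series. Compound 1 `CC(C#Cc1cccc(C(=O)NCc2cccc(F)c2)c1)N(O)C(N)=O` stands as the weaker of the two measured compounds: in an assay for inhibition of Polyunsaturated fatty acid 5-lipoxygenase (Homo sapiens), read by HPLC, with stated times of 15 min and 10 min (a higher number here means a weaker inhibitor, a lower number a stronger inhibitor), compound 1 gives 4000 nM, while compound 2 `CC(C#Cc1cccc(C(=O)NCc2ccccc2OC(F)(F)F)c1)N(O)C(N)=O` gives 1000 nM, a gap beyond the usual scatter. Compound 3 `CC(C#Cc1cccc(C(=O)NCc2ccc(Cl)cc2Cl)c1)N(O)C(N)=O` has not yet been run in this assay. It differs from compound 1 by 2,4-dichlorophenyl in place of 3-fluorophenyl on a saturated chain carbon bound to an amide-type nitrogen. Within the data shown here, no measured pair shows this exact change, so its size is uncertain; compound 2 does show that a change at the same place can move the number beyond the scatter. The step from compound 1 to compound 3 in this assay is expected to be a 2.0-fold lower number from compound 1 to compound 3 (0.30 log units; within the scatter), toward a lower number. Compound 3 is estimated to give 2000 nM, with a range of 700 nM to 6000 nM.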

Compound 3, half-maximal inhibitory concentration: 600 nM
Compound 3: the middle estimate sits 3.3-fold (0.52 log units) above what was measured; the whole stated range lies above it.
By their numbers in this assay, from the lowest: compounds 3 and 2 (each within the scatter of the next); then compound 1.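

In this assay, among these compounds, 2,4-dichlorophenyl in place of 3-fluorophenyl on a saturated chain carbon bound to an amide-type nitrogen gives a 6.7-fold lower number from compound 1 to compound 3 (0.82 log units; beyond the scatter), the first directly measured step at this position and one beyond the scatter. Compound 2 and compound 3 lie within the scatter of each other, so their two aryl groups cannot be ranked. No available evidence bears on the origin of this step. Going by these compounds, it remains open whether one chlorine alone would give the same step, and how an amine or a carboxylic acid on this phenyl ring would read.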